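The source may report more compounds than this note shows. Statements on the series, on what has been measured and on what is new or still open speak of the compounds shown alone.

In an ADME assay on a cell-free system (plasma, Homo sapiens) for metabolic stability, tested at 1 uM (a higher number here means that the compound lasts longer, a lower number that the compound disappears faster), compound 1 (`C=CC(=O)N[C@H]1CCN(S(=O)(=O)c2ccc(NC(=O)OCc3ccccc3)cc2)C1`) gives > 6 h, which is a limit of the assay and not a number. Compound 2 (`C=CC(=O)NC1CN(S(=O)(=O)c2ccc(NC(=O)OCc3ccccc3)cc2)C1`) gives > 6 h, again a limit. Compound 3 (`C=CC(=O)NC1CCN(S(=O)(=O)c2ccc(C(=O)NCCCc3ccccc3)cc2)CC1`) gives > 6 h, so it too stands only at a limit. Taken together, the half-lives known so far amount to the limit of > 6 h in this assay, at which 3 of the 3 values shown sit.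

The next compound is compound 4 (`C=CC(=O)NC1CCN(S(=O)(=O)c2ccc(C(=O)NCCC3CCCCC3)cc2)CC1`), which carries cyclohexyl in place of benzyl on a saturated chain carbon, two bonds along the chain from an amide-type nitrogen. Among the measured compounds shown here, no measured step touches this part of the molecule. For the measured compounds named here, the only one available is a step that the two limits leave unreadable from compound 1 to compound 2, which lies at a different place, on a sulfonyl sulfur, and has no readable size. It therefore offers neither a size nor a direction for the present change, and no step beyond the scatter is expected in this assay. This expectation rests on compound 3 with its limit of > 6 h, and on the same limit being shared by all the measured compounds. The expected change is a step that the limit leaves unreadable from compound 3 to compound 4. For compound 4 the estimated half-life is 8 h, with an expected range from 5 h to 20 h, and the assay will quite probably report only a limit.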

Compound 4, half-life: > 6 h
Compound 4 ended at the assay's limit; the forecaster's own chance of this, stated with the estimate: 85%; the middle value does not contradict the limit.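

In this assay compound 4 gives > 6 h as a limit of the assay and not a number. Compound 3 stands at that same limit, so no step can be read from compound 3 to compound 4. The compounds shown leave open how long any of them actually lasts, and which change, if any, would shorten the half-life.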